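Shortening the Linker of a Pyridazinone Thiourea Analog

The compounds below may be only part of what the source reports. "The series", "measured", "known", "first", "only" and "open" are said of these compounds alone.

For the measured compounds named here, compound 1 `C/N=C(\S)NCCCCCn1nc(-c2ccccc2)ccc1=O` is the one of the two compounds measured so far with the higher number. In a functional assay on the whole organism with Rattus norvegicus as the target, at a dose of 100 mg/kg (on this read-out lower numbers stand for less inhibition and higher numbers for more inhibition at the one dose given (going by the name of the read-out)), compound 1 gives 68.9%, the highest of the two numbers. Its nearest neighbour is compound 2 `C/N=C(/NC#N)NCCCCCn1nc(-c2ccccc2)ccc1=O`, which in this assay gives 47.6%; the step of a number 21.3 percentage points lower from compound 1 to compound 2 (beyond the scatter) followed a change on the amine nitrogen, where a group of 6 heavy atoms (3 carbon, 3 nitrogen; no ring) replaced a group of 4 heavy atoms (2 carbon, 1 nitrogen, 1 sulfur; no ring).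

Compound 3 `CC/N=C(\S)NCCCn1nc(-c2ccccc2)ccc1=O` differs from compound 1 elsewhere: a group of 6 heavy atoms (3 carbon, 2 nitrogen, 1 sulfur; no ring) in place of a group of 7 heavy atoms (4 carbon, 2 nitrogen, 1 sulfur; no ring), on a saturated chain carbon, three bonds along the chain from an aromatic nitrogen. Going by the values given here, the one measured step concerns a change on the amine nitrogen, not on the saturated chain carbon, so it does not bear on this change directly; it only shows that this part of the molecule is sensitive to alteration. Among the compounds with values here, with no matching precedent, the step from compound 1 to compound 3 is expected to be small or at most modest and downward, estimated at a number 13.9 percentage points lower from compound 1 to compound 3 (beyond the scatter). Compound 3 is therefore expected to give 55% in this assay, with a range from 30% to 80%.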

Compound 3, a percentage reported as inhibition, in the whole organism at one dose (the size of the read-out at that dose, not a potency): 39%
For compound 3 the middle estimate is 16 percentage points above the measured one; measured number inside the range.
By their numbers in this assay, from the lowest: compounds 3 and 2 (each within the scatter of the next); then compound 1.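

In this assay the result shows that the number also responds to a change away from the amine nitrogen: on a saturated chain carbon, three bonds along the chain from an aromatic nitrogen, a group of 6 heavy atoms in place of a group of 7 heavy atoms gives a number 29.9 percentage points lower from compound 1 to compound 3 (beyond the scatter). The two groups hold the same count of double bonds, hydrogen-bond donors and hydrogen-bond acceptors and neither carries a net charge, so those counts alone do not keep the number up, and compound 1 remains the highest of the three compounds. For the compounds shown here, nothing measured so far gives a reason for this fall.

Going by these compounds alone, the single step also leaves open how the group swap would read at other sizes, since one smaller group cannot show whether the number would keep falling, level off or recover along a series. A longer chain at this place, or an amine or a carboxylic acid in place of the sulfur-bearing end, would test whether anything can match compound 1 at 68.9% in this assay at this one dose.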